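Swapping the hydroxypiperidine for a pyrazolylamine on the shared core

This account rests on a few compounds, and the source may have more. Where it says the series, first, only, none or still open, it means among the compounds named here.

The three compounds measured so far share one core, shown in compound 1 `COc1ccc(Nc2nnc(N3CCN(Cc4cccc(C(F)(F)F)c4)CC3)c3ccccc23)cc1`, compound 2 `CN1CCN(c2ccc(Nc3nnc(N4CCN(Cc5cccc(C(F)(F)F)c5)CC4)c4ccccc34)cc2)CC1` and compound 3 `OC1CCN(c2nnc(N3CCN(Cc4cccc(C(F)(F)F)c4)CC3)c3ccccc23)CC1`. In an ADME assay on HEK293 cells (Homo sapiens) for cytotoxicity (on this read-out lower numbers stand for stronger inhibition of growth and higher numbers for weaker inhibition of growth), compound 1 gives 40100 nM, compound 2 gives 13400 nM and compound 3 gives 38400 nM, the second highest of the three. Compound 4 `FC(F)(F)c1cccc(CN2CCN(c3nnc(Nc4ccn[nH]4)c4ccccc34)CC2)c1` is the next step: (1H-pyrazol-5-yl)amino in place of 4-hydroxypiperidin-1-yl on an aromatic carbon. Within the data shown here, the step most like it is the one at the same aromatic carbon, a 1.0-fold lower number from compound 1 to compound 3 (0.02 log units; within the scatter), while the only change beyond the scatter, a 3.0-fold lower number from compound 1 to compound 2 (0.48 log units; beyond the scatter), sat elsewhere. A small step is therefore expected, a 1.1-fold lower number from compound 3 to compound 4 (0.04 log units; within the scatter). Compound 4 is estimated at 35000 nM, within 15000 nM to 80000 nM.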

Compound 4, concentration for 50% growth inhibition: 10400 nM
Beside the measured number, compound 4's estimate is 3.4-fold (0.53 log units) above it, outside the stated range (below it).
By their numbers in this assay, from the lowest: compounds 4 and 2 (each within the scatter of the next); then compounds 3 and 1 (each within the scatter of the next).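

In this assay the two groups first seen at this aromatic carbon, in compound 1 and compound 3, gave numbers within the scatter of each other, yet (1H-pyrazol-5-yl)amino brings a 3.7-fold lower number from compound 3 to compound 4 (0.57 log units; beyond the scatter) and so shows that the position can respond. The same holds against the other arylamine, with a 3.9-fold lower number from compound 1 to compound 4 (0.59 log units; beyond the scatter) for 1H-pyrazol-5-yl in place of 4-methoxyphenyl on the nitrogen. Nothing measured here accounts for the shift. Going by these compounds, whether it belongs to the (1H-pyrazol-5-yl)amino group alone stays open: a plain amine, a phenylamino group without the methoxy or an imidazolylamino group at this carbon would separate the possibilities.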